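The compounds below may be only part of what the source reports. "The series", "measured", "known", "first", "only" and "open" are said of these compounds alone.

Working notes on the series. Compound 1 `CC1(C)[C@H]2C[C@H](NC(=O)[C@H](O)C3CCCC3)[C@@H](C/C=C\CCCC(=O)O)[C@@H]1C2` gives > 800000 nM in a functional assay (plasma) for inhibition, with Oryctolagus cuniculus as the target (on this read-out higher numbers stand for weaker inhibition and lower numbers for stronger inhibition), which is a limit of the assay and not a number (the limit of > 800000 nM in this assay, at which 1 of the 3 values shown sits). Compound 2 `CCCCCc1ccc(S(=O)(=O)N[C@H]2C3CC[C@H](C3)[C@@H]2C/C=C\CCCC(=O)O)cc1` gives 800000 nM in this assay. Compound 3 `Cc1ccccc1S(=O)(=O)N[C@H]1C2CC[C@H](C2)[C@@H]1C/C=C\CCCC(=O)O` gives 6200 nM in this assay, the lowest of the two numbers shown, with the value of compound 2 standing beyond the scatter from it. Compound 4 `O=C(O)CCC/C=C\C[C@H]1[C@@H]2CCC(C2)[C@@H]1NS(=O)(=O)Cc1ccccc1` differs from compound 3 in one place only: benzyl in place of 2-methylphenyl on a sulfonyl sulfur. Among the compounds with values here, no measured pair in the set covers this kind of change, so the step from compound 3 to compound 4 is expected to be small, a 2.4-fold higher number from compound 3 to compound 4 (0.38 log units; beyond the scatter), toward weaker inhibition in this assay. Compound 4 is therefore estimated at 15000 nM, with a range of 3000 nM to 70000 nM in this assay.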

Compound 4, half-maximal inhibitory concentration: 113000 nM
Beside the measured number, compound 4's estimate is 7.5-fold (0.88 log units) below it, and the stated range ends below it.
By their numbers in this assay, from the lowest: compound 3; then compound 4; then compound 2.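

On the sulfonyl sulfur, benzyl in place of 2-methylphenyl leaves the atoms and the counted features unchanged, yet in this assay it gives an 18-fold higher number from compound 3 to compound 4 (1.26 log units; beyond the scatter). Within the data shown here, this is the only one-place step, and it shows that this position responds strongly to how the same atoms are joined. No measured property on hand bears on this step. Still open, from the compounds shown here alone, is whether a longer chain, such as phenylethyl, on the sulfonyl sulfur gives a still higher number than compound 4 does. Also open, going by these compounds, is how an amine on the aromatic ring of compound 3 would read.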